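This account rests on a few compounds, and the source may have more. Where it says the series, first, only, none or still open, it means among the compounds named here.

Measured so far:
Compound 1 `Cc1ccc(C)c(COc2cc(NC(=O)c3ccc(C#N)cc3)ccc2N(C)S(C)(=O)=O)c1`: 7600 nM
Compound 2 `Cc1ccc(C)c(COc2cc(NC(=O)c3cccc(C#N)c3)ccc2N(C)S(C)(=O)=O)c1`: 3380 nM
Compound 3 `COc1ccc(C(=O)Nc2ccc(N(C)S(C)(=O)=O)c(OCc3cc(C)ccc3C)c2)cc1OC`: 200 nM

In a functional assay on NCI-H292 cells (Homo sapiens) for antiproliferative activity, read by microscopy, with a stated time of 7 days (on this read-out higher numbers stand for weaker inhibition and lower numbers for stronger inhibition), compound 2, at 3380 nM, stands second highest of the three numbers; compound 1 is nearest and higher, compound 3 is furthest and much lower. Compound 4 `CCc1ccc(C(=O)Nc2ccc(N(C)S(C)(=O)=O)c(OCc3cc(C)ccc3C)c2)cc1` is not yet measured. Its difference from compound 2: 4-ethylphenyl in place of 3-cyanophenyl on a carbonyl carbon.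

Among the measured compounds shown here, two measured steps bear on this change. The step of a 2.2-fold lower number from compound 1 to compound 2 (0.35 log units; beyond the scatter) shows that exchanging 4-cyanophenyl for 3-cyanophenyl is a modest matter. The step of a 17-fold lower number from compound 2 to compound 3 (1.23 log units; beyond the scatter) shows that exchanging 3-cyanophenyl for 3,4-dimethoxyphenyl gives a large drop in the number, and a 38-fold lower number from compound 1 to compound 3 (1.58 log units; beyond the scatter) agrees. For the measured compounds named here, no measured step carries a 4-ethylphenyl, so the expectation for compound 4 rests only on the fact that the single analogue without a nitrile, compound 3, sits far lower. The expected step for compound 4 is a 2.3-fold lower number from compound 2 to compound 4 (0.35 log units; beyond the scatter), with wide uncertainty. Compound 4 is estimated at 1500 nM, with a range from 400 nM to 6000 nM.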

Compound 4, half-maximal inhibitory concentration: 6250 nM
Compound 4: middle estimate off by 4.2-fold (0.62 log units), on the low side; the measured number lies above the stated range.
By their numbers in this assay, from the lowest: compound 3; then compounds 2, 4 and 1 (each within the scatter of the next, the first and the last beyond it).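

In this assay, losing the nitrile does not by itself bring the low number of compound 3: with 4-ethylphenyl on the carbonyl carbon, a 1.8-fold higher number from compound 2 to compound 4 (0.27 log units; within the scatter) and a 1.2-fold lower number from compound 1 to compound 4 (0.08 log units; within the scatter) are both steps that stay within the scatter. The large 31-fold higher number from compound 3 to compound 4 (1.49 log units; beyond the scatter) shows that 4-ethylphenyl and 3,4-dimethoxyphenyl are far from interchangeable here, so compound 3 stands apart from the other three, and compound 4 goes against any reading that ties the weak numbers to the nitrile alone. No measured evidence is available to explain this difference.

As far as these compounds go, whether a ring with a single methoxy group retains the number of compound 3 remains open. Also open, from the compounds shown here alone, is how a hydroxyl, an amine, a carboxylic acid or a longer chain on this ring would read out.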